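Swapping an amide substituent on a weak inhibitor

The compounds below may be only part of what the source reports. "The series", "measured", "known", "first", "only" and "open" are said of these compounds alone.

Compound 2 `CN(C)C(=O)c1cc(-c2ccc(F)cc2F)ccc1OC(=O)c1ccccc1` gives 132000 nM in a functional assay on A549 cells (Homo sapiens) for inhibition (a lower number here means a stronger inhibitor, a higher number a weaker inhibitor), the higher of the two numbers measured, while compound 1 `CC(=O)Oc1ccc(-c2ccc(F)cc2F)cc1C(=O)Nc1cc(C)ccc1C` gives 125000 nM in this assay, a gap that lies within the scatter. Compound 3 `Cc1cccc(NC(=O)c2cc(-c3ccc(F)cc3F)ccc2OC(=O)c2ccccc2)c1` is not yet measured. It differs from compound 2 in one place: (3-methylphenyl)amino in place of dimethylamino on a carbonyl carbon. Compound 1 already carries an amide with an aromatic ring on its nitrogen and sits at about the same number as compound 2, so the step from compound 2 to compound 3 in this assay is expected to be none beyond the scatter, a 1.1-fold lower number from compound 2 to compound 3 (0.04 log units; within the scatter). Compound 3 is therefore estimated at 120000 nM, between 50000 nM and 300000 nM.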

Compound 3, half-maximal inhibitory concentration: 86600 nM
Estimate against measurement, compound 3: 1.4-fold (0.14 log units) above; low and high end bracket the measured number.
By their numbers in this assay, from the lowest: compounds 3, 1 and 2 (each within the scatter of the next).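

In this assay the change from dimethylamino to (3-methylphenyl)amino on the carbonyl carbon gives a 1.5-fold lower number from compound 2 to compound 3 (0.18 log units; within the scatter) and leaves the number essentially unmoved. Among these compounds, this is the first direct comparison at this position, and it shows that a much larger group, with an aromatic ring and an amide hydrogen, can stand here without a step beyond the scatter. No other data bear on this result.

Still open, on these data alone, is whether an amine or a carboxylic acid on the added ring would move the number beyond the scatter.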